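The compounds below may be only part of what the source reports. "The series", "measured", "known", "first", "only" and "open" are said of these compounds alone.

Measured so far:
compound 1 `COc1cc(OC)c2c(=O)cc(-c3ccc(OCCCN(C)C)cc3)oc2c1` gives 86% in a functional assay (Homo sapiens) for antiproliferative activity, read by resazurin assay, with a stated time of 48 h, tested at 20 uM; a lower number here means a weaker effect, a higher number a stronger effect of the compound at the concentration tested
compound 2 `COc1cc(OC)c2c(=O)cc(-c3ccc(OCCN)cc3)oc2c1` gives 70% in this assay
compound 3 `COc1cc(OC)c2c(=O)cc(-c3ccc(OCCCN)cc3)oc2c1` is recorded as "not determined" (no result reported) in this assay, with no result reported

Compound 3 therefore stands nowhere on the numbers; it can only be placed by structure between its neighbours. Compound 4 `COc1cc(OC)c2c(=O)cc(-c3ccc(OCC(O)CO)cc3)oc2c1` differs from it by one change: 1,2-dihydroxyethyl in place of 2-aminoethyl on a saturated chain carbon bound to an oxygen on an aromatic ring. For the measured compounds named here, the only measured step touching the chain end, a number 16 percentage points lower from compound 1 to compound 2 (beyond the scatter), exchanged one amine for another; the present change removes the amine altogether, and no measured pair covers that. The direction is uncertain, but a loss of similar or larger size looks more likely than a gain. Compound 4 is expected to give about 40% in this assay, estimated within 10% to 72%.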

Compound 4, a percentage reported as inhibition, at one concentration (the size of the read-out at that concentration, not a potency): 16%
Compound 4: middle estimate off by 24 percentage points, on the high side, and the stated range covers the measured number.
By their numbers in this assay, from the lowest: compound 4; then compound 2; then compound 1.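

In this assay, the change to 2,3-dihydroxypropoxy gives a number 54 percentage points lower from compound 2 to compound 4 (beyond the scatter) and also a number 70 percentage points lower from compound 1 to compound 4 (beyond the scatter). The earlier step, a number 16 percentage points lower from compound 1 to compound 2 (beyond the scatter), only exchanged one amine for another, whereas these show that this chain end tolerates loss of the amine far less well. The step from compound 3 cannot be read, as compound 3 has no number.

As far as these compounds go, whether the loss follows the missing nitrogen or the added hydroxyl groups stays open, and a single hydroxyl, a carboxylic acid or a piperidine at the chain end could separate these. Nothing available bears on the cause of this loss.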